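The source may hold more compounds than are shown below. What is called first, only, known or untested is meant among the compounds shown, and "the series" means these compounds.

Measured so far:
- compound 1 `CCCOC(=O)C1=C(C)NC(C)=C(C(=O)OCC)C1c1csc(-c2ccc(Cl)cc2)n1`: 4090 nM
- compound 2 `CCOC(=O)C1=C(C)NC(C)=C(C(=O)OC2CCCC2)C1c1csc(-c2ccc(Cl)cc2)n1`: 8380 nM

Both numbers come from an assay on isolated protein for antagonist activity at Voltage-dependent L-type calcium channel subunit alpha-1C (Cavia porcellus), with a stated time of 15 min; on this read-out higher numbers stand for weaker inhibition and lower numbers for stronger inhibition. Among the compounds with values here, compound 2 gives the highest of the two numbers; its nearest neighbour is compound 1, and the single measured step, a 2.0-fold higher number from compound 1 to compound 2 (0.31 log units; beyond the scatter), is the only guide available here. That step exchanged one ester substituent for another on the shared core and moved the number modestly upward.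

Compound 3 `CCOC(=O)C1=C(C)NC(C)=C(C(=O)OCCc2ccccc2)C1c1csc(-c2ccc(Cl)cc2)n1` has not been measured in this assay. Its change from compound 2 is phenethyl in place of cyclopentyl on an oxygen next to a carbonyl group. Within the data shown here, no measured pair shows this exact exchange, so the only step that bears on it is the one from propyl to cyclopentyl, which was modest in size. On that basis the step of a 1.1-fold higher number from compound 2 to compound 3 (0.03 log units; within the scatter) is expected to be small, with no strong reason to expect a move clearly beyond the scatter in either direction. Compound 3 is therefore estimated at 9000 nM in this assay, with a range from 3000 nM to 27000 nM.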

Compound 3, half-maximal inhibitory concentration: 12100 nM
Compound 3: middle estimate off by 1.3-fold (0.13 log units), on the low side, and the stated range covers the measured number.
By their numbers in this assay, from the lowest: compound 1; then compounds 2 and 3 (each within the scatter of the next).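

In this assay, phenethyl in place of cyclopentyl on an oxygen next to a carbonyl group leaves the two compounds indistinguishable (a 1.4-fold higher number from compound 2 to compound 3 (0.16 log units; within the scatter)), so a six-membered aromatic ring at the end of a two-carbon link reads the same here as a five-membered non-aromatic ring attached directly. The comparison with the propyl compound is clearer: phenyl in place of methyl on a saturated chain carbon, two bonds along the chain from an oxygen next to a carbonyl group, gives weaker inhibition (a 3.0-fold higher number from compound 1 to compound 3 (0.47 log units; beyond the scatter)), and among these three compounds both ring-bearing groups fall on the weaker side of propyl, with no compound going against that. No supporting measurement is available to explain these differences.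

As far as these compounds go, it remains open whether the small gap between the two ring-bearing groups would hold for other groups at this place, such as a benzyl group or a longer chain ending in phenyl. From the compounds shown here alone, it is also open whether an amine or a carboxylic acid on the chain would match propyl or move the number further from it.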